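A Further Methoxy Group Added to Compound 2

The compounds below may be only part of what the source reports. "The series", "measured", "known", "first", "only" and "open" are said of these compounds alone.

This account concerns a small set of compounds built on one shared core, and it follows a single change made to compound 2 `COc1ccc(CNc2nc3cc(N)cc(N)c3nc2-c2ccccc2)cc1OC`. In a functional assay on A549 cells (Homo sapiens) for inhibition, read by sulforhodamine B assay, with a stated time of 48 h (a higher number here means that more compound is tolerated, a lower number that less compound is tolerated), compound 2 gives < 100000 nM, which is a limit of the assay rather than a number. Compound 1 `Nc1cc(N)c2nc(-c3ccccc3)c(NCc3ccc(Cl)c(Cl)c3)nc2c1` carries a 3,4-dichlorophenyl group where compound 2 carries a 3,4-dimethoxyphenyl group, and in this assay compound 1 gives 69200 nM. The step that the limit leaves unreadable from compound 1 to compound 2 cannot be sized because of the limit of < 100000 nM in this assay, at which 2 of the 3 values shown sit. Compound 3 `CCOC(=O)[C@H](CCC(=O)O)NC(=O)c1ccc(Sc2nc3cc(N)cc(N)c3nc2-c2ccccc2)cc1` differs from both at the group joined through sulfur, and in this assay compound 3 gives < 100000 nM, again a limit of the assay.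

Compound 4 `COc1cc(CNc2nc3cc(N)cc(N)c3nc2-c2ccccc2)cc(OC)c1OC` has not yet been measured. It differs from compound 2 by methoxy in place of hydrogen on an aromatic carbon. For the measured compounds named here, no measured step bears directly on this change, since the only step among the measured compounds, a step that the limit leaves unreadable from compound 1 to compound 2, ends at a limit and gives no size. Going by the values given here, compound 1 at 69200 nM marks the one readable value on the shared core. Compound 4 is therefore expected to come out around 60000 nM, estimated to lie between 20000 nM and 100000 nM. The expected step that the limit leaves unreadable from compound 2 to compound 4 is estimated to be small, not beyond the scatter.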

Compound 4, concentration lethal to 50% of the cells: < 50200 nM
Compound 4: a limit, no number (the forecaster's own chance of this, stated with the estimate: 40%); at least 1.1-fold (0.07 log units) between middle value and limit.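

In this assay compound 4 gives < 50200 nM, which is a limit of the assay and not a number. For the compounds shown here, compound 2 also stands at a limit, and no step from it to compound 4 can be read. The compounds shown leave open whether methoxy in place of hydrogen on an aromatic carbon shifts the value at all.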